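A few compounds are considered here, and "the series" means these few. Any claim that something is new, unique, unknown or untested is made for them only; others in the source may bear on it.

In a physicochemical assay for solubility, read by spectrophotometry, measured as kinetic solubility, at pH 8, tested at 500 uM (on this read-out higher numbers stand for higher solubility and lower numbers for lower solubility), compound 1 (`CN(C)C(=O)c1ccncc1Nc1cc(-c2ccc3ccn(C)c3c2)c2nccnc2c1`) gives 175 ug/mL while compound 2 (`Cn1cc(NC(=O)c2ccncc2Nc2cc(-c3ccc4ccn(C)c4c3)c3nccnc3c2)cn1`) gives 2 ug/mL in the same read-out. Compound 3 (`CC(=O)N1CCCC(NC(=O)c2ccncc2Nc2cc(-c3ccc4ccn(C)c4c3)c3nccnc3c2)C1`) gives 212 ug/mL and shares the top of the range with compound 1 within the scatter. Compound 4 (`CN1CCC(N(C)C(=O)c2ccncc2Nc2cc(-c3ccc4ccn(C)c4c3)c3nccnc3c2)C1`) carries methyl(1-methylpyrrolidin-3-yl)amino in place of (1-acetylpiperidin-3-yl)amino on a carbonyl carbon. The same difference reads (1-acetylpiperidin-3-yl)carbamoyl to methyl(1-methylpyrrolidin-3-yl)carbamoyl. For the measured compounds named here, two measured steps bear on it. Exchanging dimethylamino for (1-acetylpiperidin-3-yl)amino left the number within the scatter (a 1.2-fold higher number from compound 1 to compound 3 (0.08 log units; within the scatter)). The large steps both involve 1-methyl-1H-pyrazol-4-yl (an 88-fold lower number from compound 1 to compound 2 (1.94 log units; beyond the scatter)) and (a 110-fold higher number from compound 2 to compound 3 (2.03 log units; beyond the scatter)), and the entering group carries a non-aromatic ring instead. No step beyond the scatter is therefore expected in this assay. The estimated change is small (a 1.1-fold lower number from compound 3 to compound 4 (0.03 log units; within the scatter)). For compound 4 the expected value is 200 ug/mL with an estimated range from 110 ug/mL to 270 ug/mL in this read-out.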

Compound 4, solubility: 245 ug/mL
The estimate for compound 4 lay 1.2-fold (0.09 log units) below the measured number; the range from low to high includes it.
By their numbers in this assay, from the lowest: compound 2; then compounds 1, 3 and 4 (each within the scatter of the next).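

In this assay the carbonyl carbon accepts methyl(1-methylpyrrolidin-3-yl)amino with a 1.2-fold higher number from compound 3 to compound 4 (0.06 log units; within the scatter) and with a 1.4-fold higher number from compound 1 to compound 4 (0.15 log units; within the scatter) so a second non-aromatic ring on this amide stays in the same group as compound 1 and compound 3. This one change alters the ring size and removes both the acetyl and the amide hydrogen, yet the number does not move beyond the scatter. For the compounds shown here, the step from the pyrazole amide is large, with a 120-fold higher number from compound 2 to compound 4 (2.09 log units; beyond the scatter) and compound 2 remains the only low compound of the four and the only one with an aromatic ring on this amide.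

On these data alone, whether the low number belongs to 1-methyl-1H-pyrazol-4-yl alone or would recur with a phenyl on the same nitrogen stays open. Nothing at hand bears on the reason for these steps.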